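A few compounds are considered here, and "the series" means these few. Any claim that something is new, unique, unknown or untested is made for them only; others in the source may bear on it.

Values so far in an ADME assay on microsomes from liver (Homo sapiens) for pharmacokinetics, read by LC-MS, with a stated time of 60 min, tested at 1 uM (a higher number here means faster removal of the compound, a lower number slower removal), are these.

Compound 1 `O=C(NCc1ccc(S(=O)(=O)c2cccc(C(F)(F)F)c2)cc1)N1Cc2ccncc2C1` gives 14 mL/min/kg
Compound 2 `CCCn1cc(S(=O)(=O)c2ccc(CNC(=O)N3Cc4ccncc4C3)cc2)cn1` gives 11 mL/min/kg
Compound 3 `CC(=O)N1CCC(S(=O)(=O)c2ccc(CNC(=O)N3Cc4ccncc4C3)cc2)CC1` gives 6 mL/min/kg

Compound 3 stands at the low end of this short series. The step of a 1.8-fold lower number from compound 2 to compound 3 (0.26 log units; within the scatter) lies within the scatter, while the step of a 2.3-fold lower number from compound 1 to compound 3 (0.37 log units; beyond the scatter) is modest and lies beyond it. The change to compound 4 `CCC(=O)N1CCC(S(=O)(=O)c2ccc(CNC(=O)N3Cc4ccncc4C3)cc2)CC1` is methyl in place of hydrogen on a saturated chain carbon bound to a carbonyl carbon and it turns acetyl into propanoyl. Going by the values given here, no measured step touches this acyl group. The three measured steps, including a 1.3-fold lower number from compound 1 to compound 2 (0.10 log units; within the scatter) as well, all replace the whole group on the sulfonyl sulfur, so they bear on it only loosely. In this assay no shift beyond the scatter is expected, at most a slight rise. The expected step is a 1.3-fold higher number from compound 3 to compound 4 (0.12 log units; within the scatter) and it stays within the scatter. For compound 4 the estimate is 8 mL/min/kg with an expected range from 4 mL/min/kg to 16 mL/min/kg as the likely span.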

Compound 4, clearance: 11 mL/min/kg
Estimate against measurement, compound 4: 1.4-fold (0.14 log units) below; measured number inside the range.
By their numbers in this assay, from the lowest: compounds 3, 2, 4 and 1 (each within the scatter of the next, the first and the last beyond it).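

Going by these compounds alone, compound 4 gives the first reading at the acyl group itself: in this assay, methyl in place of hydrogen on a saturated chain carbon bound to a carbonyl carbon gives a 1.8-fold higher number from compound 3 to compound 4 (0.26 log units; within the scatter), so turning acetyl into propanoyl cannot be told from the scatter. With 1-propanoylpiperidin-4-yl on the sulfonyl sulfur the steps read no change at the digits printed from compound 2 to compound 4 (within the scatter) and a 1.3-fold lower number from compound 1 to compound 4 (0.10 log units; within the scatter), so the gap seen between compound 1 and compound 3 does not appear here. Nothing measured here accounts for these numbers.

As far as these compounds go, whether a longer chain such as butanoyl, or an amine on the acyl group, would move the number beyond the scatter stays open.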